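Notes on replacing 2-oxopyrrolidin-1-yl with 3-methyl-2-oxoimidazolidin-1-yl

The source may report more compounds than this note shows. Statements on the series, on what has been measured and on what is new or still open speak of the compounds shown alone.

Among the compounds with values here, compound 2 `Cc1nc(N2CCC(N3CCCC3=O)CC2)nc2ccc(NC(=O)/C=C/c3ccc(OC(F)(F)F)cc3)cc12` gives 12 nM in a functional assay on CHO-K1 cells for antagonist activity at melanin-concentrating hormone receptor 1 (Homo sapiens), read by inositol phosphate accumulation, with stated times of 10 min and 45 min (a lower number here means a stronger inhibitor, a higher number a weaker inhibitor), the lowest of the two numbers so far; compound 1 `Cc1nc(N2CCC(NS(=O)(=O)N(C)C)CC2)nc2ccc(NC(=O)/C=C/c3ccc(OC(F)(F)F)cc3)cc12` gives 31 nM. Within the data shown here, the only measured step is a 2.6-fold lower number from compound 1 to compound 2 (0.41 log units; beyond the scatter), which changed the group on the same saturated ring carbon that is varied next. Compound 3 `Cc1nc(N2CCC(N3CCN(C)C3=O)CC2)nc2ccc(NC(=O)/C=C/c3ccc(OC(F)(F)F)cc3)cc12` carries 3-methyl-2-oxoimidazolidin-1-yl in place of 2-oxopyrrolidin-1-yl on a saturated ring carbon. That earlier step shows the group at this position can move the number modestly, but it exchanged quite different groups, whereas here one five-membered non-aromatic ring with 1 hetero atom gives way to one with 2 hetero atoms plus a methyl. Among the measured compounds shown here, no measured step tests this particular swap. The expectation for compound 3 is therefore a number close to that of compound 2, with a 1.3-fold higher number from compound 2 to compound 3 (0.10 log units; within the scatter) within the scatter or at most modest in either direction. Compound 3 is estimated at 15 nM, between 6 nM and 40 nM.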

Compound 3, half-maximal inhibitory concentration: 21 nM
Compound 3: the middle estimate sits 1.4-fold (0.15 log units) below what was measured, and the stated range covers the measured number.
By their numbers in this assay, from the lowest: compounds 2, 3 and 1 (each within the scatter of the next, the first and the last beyond it).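

In this assay, putting 3-methyl-2-oxoimidazolidin-1-yl in place of 2-oxopyrrolidin-1-yl on this saturated ring carbon gives a step that cannot be told from repeat-measurement noise (a 1.8-fold higher number from compound 2 to compound 3 (0.24 log units; within the scatter)), so this position tolerates a second ring hetero atom plus a methyl without a readable change. The step from the sulfamoyl compound is also within the scatter (a 1.5-fold lower number from compound 1 to compound 3 (0.17 log units; within the scatter)), which places compound 3 in reach of both neighbours, although compound 2 and compound 1 are separated from each other. Nothing available bears on why these numbers fall as they do.

Open, as far as these compounds go, is how an amine or a carboxylic acid on this saturated ring carbon would read in this assay. Also open, from the compounds shown here alone, is whether the ring methyl and the second ring nitrogen act separately, which the 2-oxoimidazolidin-1-yl group lacking that methyl would address.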